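Swapping thiophene for a bromophenyl group in compound 3

The source may report more compounds than this note shows. Statements on the series, on what has been measured and on what is new or still open speak of the compounds shown alone.

compound 1 `COc1cc(CCC(=O)Nc2ccc(C(=O)NO)cc2)ccc1OCc1ccccc1`: 600000 nM
compound 2 `COc1cc(CCC(=O)Nc2ccc(C(=O)NO)cc2)ccc1OCc1cccs1`: 80000 nM

Both values come from a functional assay on A549 cells (Homo sapiens) for antiproliferative activity, read by MTT assay, with a stated time of 2 days; on this read-out higher numbers stand for weaker inhibition and lower numbers for stronger inhibition. Compound 2 has the lower of the two numbers, so it is the stronger inhibitor of this pair. The next compound is compound 3 `COc1cc(CCC(=O)Nc2ccc(C(=O)NO)cc2)ccc1OCc1ccccc1Br`, which differs from compound 2 in one place: 2-bromophenyl in place of thiophen-2-yl on a saturated chain carbon bound to an oxygen on an aromatic ring. In other words, 2-bromophenyl takes the place of thiophen-2-yl.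

For the measured compounds named here, only one measured step bears on this change: a 7.5-fold lower number from compound 1 to compound 2 (0.88 log units; beyond the scatter), where thiophen-2-yl replaced phenyl at the same place. Compound 3 returns to a six-membered carbon ring, so part of that gain may be lost. Going by the values given here, no measured compound shows what the bromine adds, which leaves the estimate loose. The expected change is a 2.5-fold higher number from compound 2 to compound 3 (0.40 log units; beyond the scatter), towards weaker inhibition. For compound 3 the estimated value is 200000 nM, with an expected range of 50000 nM to 700000 nM.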

Compound 3, half-maximal inhibitory concentration: 600000 nM
For compound 3 the middle estimate is 3.0-fold (0.48 log units) below the measured one; measured number inside the range.
By their numbers in this assay, from the lowest: compound 2; then compounds 1 and 3 (each within the scatter of the next).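

Moving to 2-bromophenyl gives a 7.5-fold higher number from compound 2 to compound 3 (0.88 log units; beyond the scatter), so the lower number of compound 2 does not carry over to this substituted six-membered carbon ring. Bromo in place of hydrogen on an aromatic carbon gives no change at the digits printed from compound 1 to compound 3 (within the scatter), which shows that bromo on this ring, at the place it occupies in compound 3, makes no difference beyond the scatter. Among these three compounds, thiophen-2-yl alone stands apart from the other two, and no evidence here accounts for that.

The compounds shown leave open whether the lower number goes with the sulfur or with the five-membered ring, a question that a furan-2-yl group at this place could help to separate. Also open, from the compounds shown here alone, is how chloro or methoxy, or bromo on another ring carbon, would read.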